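The compounds below may be only part of what the source reports. "The series", "measured", "known", "first", "only" and "open" are said of these compounds alone.

Measured so far in a functional assay on MKN-45 cells (Homo sapiens) for inhibition, read by sulforhodamine B assay, with a stated time of 48 h; on this read-out lower numbers stand for stronger inhibition of growth and higher numbers for weaker inhibition of growth:
- compound 1 `CCCCCCCCCCCC[C@@H](O)[C@H]1CC[C@H]([C@H](O)CCCCCCCCCCNC(=O)c2ccnn2C)O1`: 7410 nM
- compound 2 `CCCCCCCCCCCC[C@@H](O)[C@H]1CC[C@H]([C@H](O)CCCCCCCCCCN(C)C(=O)c2ccnn2C)O1`: 11000 nM

Compound 2, at 11000 nM, cannot be separated from compound 1 on these two numbers, as their gap lies within the scatter.

Next is compound 3 `CCCCCCCCCCCC[C@@H](O)[C@H]1CC[C@H]([C@H](O)CCCCCCCCCCNCc2ccnn2C)O1`, and the change is ((1-methyl-1H-pyrazol-5-yl)methyl)amino in place of methyl((1-methyl-1H-pyrazol-5-yl)carbonyl)amino on a saturated chain carbon, ten or more bonds along the chain from an oxygen on a saturated carbon and a saturated ring carbon. The entering ((1-methyl-1H-pyrazol-5-yl)methyl)amino group sits on a saturated chain carbon.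

Among the measured compounds shown here, only one measured step bears on this, and only on the methyl part of the change: a 1.5-fold higher number from compound 1 to compound 2 (0.17 log units; within the scatter). For the measured compounds named here, no measured compound shows what happens when the carbonyl is lost, so that part rests on no data. In this assay, no step beyond the scatter is therefore expected, though the direction is weakly held and the range is kept wide.

The expected change is a 1.6-fold lower number from compound 2 to compound 3 (0.20 log units; within the scatter).

The estimate for compound 3 is 7000 nM, with an expected range of 2500 nM to 20000 nM.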

Compound 3, concentration for 50% growth inhibition: 1820 nM
The estimate for compound 3 lay 3.8-fold (0.59 log units) above the measured number, outside the stated range (below it).
By their numbers in this assay, from the lowest: compound 3; then compounds 1 and 2 (each within the scatter of the next).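

In this assay, this position responds to the change at the carbonyl in a way it did not respond to the methyl on the amide nitrogen. With (1-methyl-1H-pyrazol-5-yl)methyl in place of (1-methyl-1H-pyrazol-5-yl)carbonyl on the amine nitrogen, the result is a 4.1-fold lower number from compound 1 to compound 3 (0.61 log units; beyond the scatter), and the full replacement of methyl((1-methyl-1H-pyrazol-5-yl)carbonyl)amino by ((1-methyl-1H-pyrazol-5-yl)methyl)amino gives a 6.0-fold lower number from compound 2 to compound 3 (0.78 log units; beyond the scatter), both beyond the scatter, whereas a 1.5-fold higher number from compound 1 to compound 2 (0.17 log units; within the scatter) stays within it. Among these three compounds, the change in growth inhibition therefore goes with the loss of the carbonyl and not with the nitrogen methyl, though no measurement at hand accounts for this step.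

The compounds shown leave open whether the amine nitrogen itself or only the absence of the carbonyl carries the step, a question that a sulfonamide or an ether linkage at the same chain carbon would address. They also leave open how much the pyrazole contributes once the amine is present, and whether an N-methyl amine or a phenyl ring in place of the pyrazole would hold the value of compound 3 at 1820 nM.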